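Hydroxy to methoxy on compound 1

The source may hold more compounds than are shown below. What is called first, only, known or untested is meant among the compounds shown, and "the series" means these compounds.

Compound 1 `COc1cc(C(=O)c2ccc(OC)c(O)c2OC)cc(OC)c1O` gives 611 nM for growth inhibition
Compound 2 `COc1cc(C(=O)c2ccc3c(c2)oc(=O)n3S(C)(=O)=O)cc(OC)c1OC` gives 2000 nM for growth inhibition

In a functional assay on HCT-15 cells (Homo sapiens) for cytotoxicity, read by sulforhodamine B assay, with a stated time of 48 h (on this read-out higher numbers stand for weaker inhibition of growth and lower numbers for stronger inhibition of growth), compound 1 holds the lower of the two numbers, at 611 nM, and compound 2 stands at 2000 nM, a gap beyond the usual scatter. Of these two, compound 1 therefore shows the stronger inhibition of growth.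

The next compound is compound 3 `COc1ccc(C(=O)c2cc(OC)c(OC)c(OC)c2)c(OC)c1O`. It differs from compound 1 in one place (methyl in place of hydrogen on an oxygen on an aromatic ring), with methyl in place of hydrogen on an oxygen on an aromatic ring, so that a hydroxy becomes a methoxy.

Going by the values given here, no measured pair here shows this change, and compound 2 differs too widely from compound 1 to serve as a direct guide. A moderate move towards a lower number in this assay is nevertheless expected, probably beyond the scatter, though the direction remains uncertain. The estimated step reads a 3.1-fold lower number from compound 1 to compound 3 (0.49 log units; beyond the scatter) and is only an expectation. Compound 3 is expected at 200 nM, with an estimated range from 40 nM to 900 nM for a repeated measurement.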

Compound 3, concentration for 50% growth inhibition: 10.6 nM
Beside the measured number, compound 3's estimate is 19-fold (1.28 log units) above it; measured number below the stated range.
By their numbers in this assay, from the lowest: compound 3; then compound 1; then compound 2.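

In this assay, turning this one hydroxy into a methoxy gives a 58-fold lower number from compound 1 to compound 3 (1.76 log units; beyond the scatter), a large step and the first reading of this change among the compounds shown. At this oxygen on an aromatic ring, then, the hydrogen is not needed for strong inhibition of growth: the compound with the methyl in its place gives the lowest number of the three. The change is small, a single added carbon with no ring and no net charge, yet the number moves far, and no measurement at hand says why this single methyl counts for so much.

The compounds shown leave open whether the gain belongs to the methyl itself or would also appear with a longer chain such as ethoxy, or with an amine in place of the oxygen at this position. Going by these compounds alone, they also leave open what the one hydroxy still present on an aromatic ring in compound 3 contributes, since no compound here differs from compound 3 at that oxygen alone.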